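A few compounds are considered here, and "the series" means these few. Any claim that something is new, unique, unknown or untested is made for them only; others in the source may bear on it.

Compound 1 `CCCC1=C(OC)C(CCC)(CCC)C(=O)/C(=C(O)\C=C\c2ccc(I)cc2)C1=O`: 1.8 uM
Compound 2 `CCCC1=C(OCCC(C)C)C(CCC)(CCC)C(=O)/C(=C(O)\C=C\c2ccccc2)C1=O`: 9.1 uM

In a functional assay on MCF7 cells (Homo sapiens) for antiproliferative activity, read by sulforhodamine B assay, with a stated time of 3 days (on this read-out higher numbers stand for an effect only at larger amounts of compound and lower numbers for an effect already at smaller amounts), compound 2 gives 9.1 uM, the higher of the two numbers. Compound 1 stands lower at 1.8 uM, a gap beyond the usual scatter. These two compounds differ in more than one place, so the gap cannot be tied to any single change.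

Compound 3 `CCCC1=C(OCC)C(CCC)(CCC)C(=O)/C(=C(O)\C=C\c2ccccc2)C1=O` has a simpler change from compound 2: hydrogen in place of isopropyl on a saturated chain carbon, two bonds along the chain from an oxygen on an unsaturated carbon. Hydrogen takes the place of isopropyl on a saturated chain carbon, two bonds along the chain from an oxygen on an unsaturated carbon, which turns isopentyloxy into ethoxy.

Within the data shown here, no measured pair shows this change alone. In this assay, a small move toward lower numbers is expected, possibly none beyond the scatter. The estimated change is a 1.5-fold lower number from compound 2 to compound 3 (0.18 log units; within the scatter). For compound 3 the expected value is 6 uM, with an estimated range of 2.5 uM to 14 uM.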

Compound 3, concentration for half-maximal effect: 2.6 uM
The estimate for compound 3 lay 2.3-fold (0.36 log units) above the measured number, and the stated range covers the measured number.
By their numbers in this assay, from the lowest: compounds 1 and 3 (each within the scatter of the next); then compound 2.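

Among these compounds, the first single-change comparison in this set comes from this assay: going from isopentyloxy to ethoxy gives a 3.5-fold lower number from compound 2 to compound 3 (0.54 log units; beyond the scatter). This shows that the chain on this oxygen is not a silent position, as hydrogen in place of isopropyl on a saturated chain carbon, two bonds along the chain from an oxygen on an unsaturated carbon, moves the number beyond the usual scatter. Nothing measured here explains why the number moves with this change.

From the compounds shown here alone, a single step gives only two points on this chain, so it remains open whether the number follows chain length or the branching of isopentyl. Also open, going by these compounds, is how a straight butyl chain, or an amine or carboxylic acid carried on the chain, would read in this assay.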